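Stability Holds Near the Top of the Scale

A few compounds are considered here, and "the series" means these few. Any claim that something is new, unique, unknown or untested is made for them only; others in the source may bear on it.

In an ADME assay on microsomes from liver (Homo sapiens) for metabolic stability, using NADPH, with a stated time of 10 min (on this read-out higher numbers stand for a more stable compound and lower numbers for a less stable compound), compound 1 (`NCCCCN(C[C@H]1Cc2cccnc2CN1)[C@H]1CCCc2cccnc21`) gives 96%, compound 2 (`CN(C[C@@H]1Cc2ncccc2CN1)[C@H]1CCCc2cccnc21`) gives 100% and compound 3 (`NC(=O)NC/C=C\CN(C[C@H]1Cc2ncccc2CN1)[C@H]1CCCc2cccnc21`) gives 100%. Compound 3 is therefore level with compound 2 and within the scatter of compound 1, so the three values do not separate, despite their different structures. The next compound to be tested is compound 4 (`c1cnc2c(c1)CN[C@@H](CN(CCCCNC1COC1)[C@H]1CCCc3cccnc31)C2`). Its structure differs from that of compound 3 by a group of 8 heavy atoms (6 carbon, 1 nitrogen, 1 oxygen; one four-membered non-aromatic ring with 1 hetero atom) in place of a group of 7 heavy atoms (4 carbon, 2 nitrogen, 1 oxygen; no ring), on a saturated chain carbon bound to an amine nitrogen, a change on a saturated chain carbon bound to an amine nitrogen. For the measured compounds named here, no measured pair isolates this change, so any forecast for this assay has to rest on the overall level of the series. That expectation leans on compound 1, which retains 96%. At most a small fall is expected, with no step beyond the scatter. The estimated change is a number 6 percentage points lower from compound 3 to compound 4 (within the scatter), which is expected to stay within the scatter. For compound 4 the expected value is 94%, with an estimated range of 82% to 100%.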

Compound 4, percent of the compound remaining: 97%
Compound 4: middle estimate off by 3 percentage points, on the low side, and the stated range covers the measured number.
By their numbers in this assay, from the lowest: compounds 1, 4, 2 and 3 (each within the scatter of the next).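

In this assay, the exchange of the open-chain group with no ring for the group with one four-membered non-aromatic ring with 1 hetero atom, on a saturated chain carbon bound to an amine nitrogen, gives a number 3 percentage points lower from compound 3 to compound 4 (within the scatter). For the compounds shown here, this is the first step that can be read directly at this place, and it shows that this exchange does not separate the two compounds on this read-out, even though a ring enters and the 2 double bonds outside aromatic rings leave. No measured information accounts for this result.

From the compounds shown here alone, whether a carboxylic acid or a morpholine ring at this place would hold the number equally well remains open. Also open, going by these compounds, is whether any group here can move the read-out beyond the scatter.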